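The source may hold more compounds than are shown below. What is called first, only, known or untested is meant among the compounds shown, and "the series" means these compounds.

Series notes on solubility. Compound 1 `COCCCn1c(=O)[nH]c2c(N)nc(C(F)(F)F)cc21` carries a 2-methoxyethyl group on a saturated chain carbon bound to an aromatic nitrogen of the shared core. In a physicochemical assay for solubility (a lower number here means a less soluble compound, a higher number a more soluble compound), compound 1 gives 23 ug/mL, numerically the highest of the three values in hand, though compound 3 is not separated from it beyond the scatter. Compound 2 `Cc1cccc(Cn2c(=O)[nH]c3c(N)nc(C(F)(F)F)cc32)n1` gives 3 ug/mL in this assay, and compound 3 `Cc1ccc(Cn2c(=O)[nH]c3c(N)nc(C(F)(F)F)cc32)nn1` gives 21 ug/mL. The two measured steps away from compound 1 diverge: a 7.7-fold lower number from compound 1 to compound 2 (0.88 log units; beyond the scatter), whereas a 1.1-fold lower number from compound 1 to compound 3 (0.04 log units; within the scatter); between those two, a 7.0-fold higher number from compound 2 to compound 3 (0.85 log units; beyond the scatter).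

Compound 4 `Cc1nc(Cn2c(=O)[nH]c3c(N)nc(C(F)(F)F)cc32)co1` is not yet measured. Its difference from compound 1 is 2-methyl-1,3-oxazol-4-yl in place of 2-methoxyethyl on a saturated chain carbon bound to an aromatic nitrogen. As with the steps to compound 2 and compound 3, the 2-methoxyethyl is exchanged for a methyl-bearing aromatic heterocycle; the measured outcomes of such exchanges span no change beyond the scatter to a modest drop, and nothing in hand tells which case applies here. For compound 4 in this assay a step of a 1.9-fold lower number from compound 1 to compound 4 (0.28 log units; within the scatter) is expected, downward, possibly not exceeding the scatter. The estimate for compound 4 is 12 ug/mL, with a range from 4 ug/mL to 30 ug/mL.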

Compound 4, solubility: 35 ug/mL
Estimate against measurement, compound 4: 2.9-fold (0.46 log units) below; measured number outside the range, above it.
By their numbers in this assay, from the lowest: compound 2; then compounds 3, 1 and 4 (each within the scatter of the next).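

In this assay the exchange of 2-methoxyethyl for 2-methyl-1,3-oxazol-4-yl on a saturated chain carbon bound to an aromatic nitrogen gives a 1.5-fold higher number from compound 1 to compound 4 (0.18 log units; within the scatter) so, after compound 3, a second methyl-bearing aromatic heterocycle stays level with compound 1. The two heterocycles also stay level with each other, with a 1.7-fold higher number from compound 3 to compound 4 (0.22 log units; within the scatter) set against a 12-fold higher number from compound 2 to compound 4 (1.07 log units; beyond the scatter) and compound 2 alone falls beyond the scatter from the other three. The drop therefore does not follow from a methyl-bearing aromatic heterocycle as such, with compound 2 the only one of the three that goes against the rest, and no measurement at hand accounts for this difference.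

Open, going by these compounds, is whether an amine such as a dimethylaminoethyl chain, or a carboxylic acid, at this place would move the number beyond the scatter from compound 1 in either direction. Also open, on these data alone, is whether the low number of compound 2 belongs to 6-methylpyridin-2-yl alone or extends to other pyridine groups.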